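Bromination of a Naphthoquinone Amine: Expected Effect on Cytotoxicity

This account rests on a few compounds, and the source may have more. Where it says the series, first, only, none or still open, it means among the compounds named here.

Compound 1 `Cc1ccc(S(=O)(=O)/N=C(/CCNC2=CC(=O)c3ccccc3C2=O)Nc2ccccc2[N+](=O)[O-])cc1` gives 5010 nM in a functional assay on A549 cells (Homo sapiens) for cytotoxicity, read by MTT assay, with a stated time of 48 h; on this read-out lower numbers stand for stronger inhibition and higher numbers for weaker inhibition.
Compound 2 `COc1ccc(N/C(CCNC2=CC(=O)c3ccccc3C2=O)=N\S(=O)(=O)c2ccc(C)cc2)cc1OC` gives 20500 nM in this assay.

Among the compounds with values here, compound 2 holds the highest number of the two compounds measured, and the only step known is the one from compound 1 to compound 2, which is a 4.1-fold higher number from compound 1 to compound 2 (0.61 log units; beyond the scatter) and concerns the aryl group on the amine nitrogen. Compound 3 `COc1ccc(N/C(CCNC2=C(Br)C(=O)c3ccccc3C2=O)=N\S(=O)(=O)c2ccc(C)cc2)cc1OC` keeps the 3,4-dimethoxyphenyl of compound 2 and differs only on the quinone part of the shared core: bromo in place of hydrogen on a double-bonded ring carbon. Within the data shown here, no measured step touches this position, so the one known step does not bear on the change, and there is no basis for predicting a large shift. A change of compound 3 that stays near the scatter is expected, a 1.7-fold lower number from compound 2 to compound 3 (0.23 log units; within the scatter), with some lean toward a lower number. Compound 3 is estimated at 12000 nM, within a range from 4000 nM to 40000 nM.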

Compound 3, half-maximal inhibitory concentration: 17500 nM
For compound 3 the middle estimate is 1.5-fold (0.16 log units) below the measured one; the measured number falls inside the stated range.
By their numbers in this assay, from the lowest: compound 1; then compounds 3 and 2 (each within the scatter of the next).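

In this assay, bromo in place of hydrogen on the double-bonded ring carbon gives a 1.2-fold lower number from compound 2 to compound 3 (0.07 log units; within the scatter), so compound 2 and compound 3 cannot be told apart in this test. Within the data shown here, this is the first information about this position, since the earlier step, a 4.1-fold higher number from compound 1 to compound 2 (0.61 log units; beyond the scatter), concerned the aryl group on the amine nitrogen and lay beyond the scatter. Nothing available here explains the result.

Going by these compounds, it remains open whether a chlorine, a methyl or an amine on the same ring carbon would also leave the number within the scatter. On these data alone, it is also open whether bromo would do so alongside the 2-nitrophenyl of compound 1, because this single pair carries the 3,4-dimethoxyphenyl only.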